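This account rests on a few compounds, and the source may have more. Where it says the series, first, only, none or still open, it means among the compounds named here.

The measured compounds:

compound 1, `CN(C)c1ccc(/C=N/NC(=N)NO)cc1`: in an ADME assay on HeLa cells (Homo sapiens) for cytotoxicity (a higher number here means that more compound is tolerated, a lower number that less compound is tolerated), compound 1 gives > 100000 nM, which is a limit of the assay rather than a number.

compound 2, `N/C(=N\O)N/N=C/c1ccccc1O`: in this assay compound 2 gives > 100000 nM, again a limit.

Since both values are limits, neither compound can be placed above or below the other; where compound 1 stands is told only by the limit of > 100000 nM in this assay, at which 2 of the 2 values shown sit. Both compounds tolerate at least as much compound as the assay can report.

Compound 3, `N=C(NO)N/N=C/c1ccccc1`, has not yet been tested in this assay. It differs from compound 1 by hydrogen in place of dimethylamino on an aromatic carbon, in words: hydrogen in place of dimethylamino on an aromatic carbon. Within the data shown here, no pair of measured compounds shows what this kind of change does in this assay. Compound 2, which carries a different group on the shared core, also sits at the limit, so nothing points toward a loss of tolerance when the dimethylamino group goes. The expected step is a number no higher from compound 1 to compound 3 (the limit leaves the size open), nothing beyond the scatter. Compound 3 is therefore estimated to come out at 100000 nM, within a range of 30000 nM to 300000 nM, and most likely again as a limit.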

Compound 3, half-maximal cytotoxic concentration: > 100000 nM
Compound 3 was reported as a limit; the forecaster's own chance of this, stated with the estimate: 80%; the middle value lies on the limit itself.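

No step can be read from compound 1 to compound 3, since both results in this assay are limits of the assay rather than numbers: the limit of > 100000 nM in this assay, at which 3 of the 3 values shown sit.

The compounds shown leave open how much of each compound the cells would tolerate beyond that limit, and whether any change on the shared core would give a readable number.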